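Removing the urea from a sulfonyl side chain

This account rests on a few compounds, and the source may have more. Where it says the series, first, only, none or still open, it means among the compounds named here.

Of the compounds shown here, three sharing one core have been measured in a physicochemical assay for permeability, using PAMPA, at pH 7.4; on this read-out lower numbers stand for lower permeability and higher numbers for higher permeability. Compound 1 `CNC(=O)NCCS(=O)(=O)NC(=O)c1ccc(Nc2nc(NC3(c4ccc(Cl)cc4)CC3)nc(OCC(F)(F)F)n2)cc1` gives 40 nm/s and stands lowest of the three. Compound 3 `CC(C)NC(=O)NCCS(=O)(=O)NC(=O)c1ccc(Nc2nc(NC3(c4ccc(Cl)cc4)CC3)nc(OCC(F)(F)F)n2)cc1` gives 45 nm/s, and the step of a 1.1-fold higher number from compound 1 to compound 3 (0.05 log units; within the scatter) stays within the scatter. Compound 2 `O=C(NS(=O)(=O)c1ccc(F)cc1)c1ccc(Nc2nc(NC3(c4ccc(Cl)cc4)CC3)nc(OCC(F)(F)F)n2)cc1`, which carries a 4-fluorophenyl on the sulfonyl sulfur, gives 193 nm/s, and the step of a 4.8-fold higher number from compound 1 to compound 2 (0.68 log units; beyond the scatter) is the only one here that leaves the scatter.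

Compound 4 `CC(C)NCCS(=O)(=O)NC(=O)c1ccc(Nc2nc(NC3(c4ccc(Cl)cc4)CC3)nc(OCC(F)(F)F)n2)cc1` has not yet been measured. It differs from compound 1 in one place: isopropyl in place of methylcarbamoyl on an amine nitrogen. The change sits on the amine nitrogen of the 2-((methylcarbamoyl)amino)ethyl chain, so the chain is kept but its carbamoyl end is cut away. Among the measured compounds shown here, no measured step does exactly this. The step of a 1.1-fold higher number from compound 1 to compound 3 (0.05 log units; within the scatter) only swaps the alkyl on the amide-type nitrogen and keeps the carbamoyl, and it stays within the scatter. The step of a 4.8-fold higher number from compound 1 to compound 2 (0.68 log units; beyond the scatter) removes the whole chain but also brings in a ring, so it cannot be read across directly. For the measured compounds named here, with no closely matching precedent, a step within the scatter or a small drop is the expectation, as a 1.1-fold lower number from compound 1 to compound 4 (0.06 log units; within the scatter). Compound 4 is therefore estimated at 35 nm/s, with a range from 10 nm/s to 110 nm/s.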

Compound 4, apparent permeability: 45 nm/s
The estimate for compound 4 lay 1.3-fold (0.11 log units) below the measured number; the range from low to high includes it.
By their numbers in this assay, from the lowest: compounds 1, 3 and 4 (each within the scatter of the next); then compound 2.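

Cutting away the carbamoyl end of the chain, so that isopropyl stands on the amine nitrogen, leaves the number in this assay within the scatter whether the urea carried a methyl (a 1.1-fold higher number from compound 1 to compound 4 (0.05 log units; within the scatter)) or an isopropyl (no change at the digits printed from compound 3 to compound 4 (within the scatter)). The earlier compounds shown here showed only that the alkyl on the urea could be swapped within the scatter, whereas the 2-(isopropylamino)ethyl chain now shows that the urea can go altogether and the number still stays well apart from that of the 4-fluorophenyl compound (a 4.3-fold lower number from compound 2 to compound 4 (0.63 log units; beyond the scatter)). So in this set, the step beyond the scatter appears only where the whole chain on the sulfonyl sulfur gives way to the 4-fluorophenyl, and nothing available offers an explanation for these numbers.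

Still open, as far as these compounds go, is how a carboxylic acid at the end of the ethyl chain, or a longer chain, would read in this assay. Also open, from the compounds shown here alone, is whether the 4-fluorophenyl is needed for the higher number, since a plain phenyl or a small alkyl such as methyl on the sulfonyl sulfur could separate the ring from the loss of the chain.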